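This account rests on a few compounds, and the source may have more. Where it says the series, first, only, none or still open, it means among the compounds named here.

Compound 1 `COc1cccc(CCOc2ccc(-c3c(C)nc(C)c([C@H](OC(C)(C)C)C(=O)O)c3N3CCC(C)(C)CC3)cc2)c1` in an ADME assay on microsomes from liver (Homo sapiens) for metabolic stability, read by LC-MS, tested at 0.5 uM (a higher number here means that the compound lasts longer, a lower number that the compound disappears faster), gives > 2 h, which is a limit of the assay rather than a number. Compound 2 `Cc1cc(CCOc2ccc(-c3c(C)nc(C)c([C@H](OC(C)(C)C)C(=O)O)c3N3CCC(C)(C)CC3)cc2)ccc1F` in this assay gives > 2 h, again a limit of the assay. Compound 3 `Cc1nc(C)c([C@H](OC(C)(C)C)C(=O)O)c(N2CCC(C)(C)CC2)c1-c1ccc(OCCc2ccc(F)cc2F)cc1` in this assay gives 1.08 h.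

Within the data shown here, compound 3 therefore stands as the only compound with a read number; the other two sit at the limit of > 2 h in this assay, at which 2 of the 3 values shown sit. The step from compound 1 to compound 3 is an at least 1.8-fold lower number from compound 1 to compound 3 (0.26 log units; that floor lies within the scatter), and that from compound 2 to compound 3 is an at least 1.8-fold lower number from compound 2 to compound 3 (0.26 log units; that floor lies within the scatter); the step from compound 1 to compound 2 is a step that the two limits leave unreadable from compound 1 to compound 2.

Compound 4 `Cc1nc(C)c([C@H](OC(C)(C)C)C(=O)O)c(N2CCC(C)(C)CC2)c1-c1ccc(OCCc2ccc(F)c(F)c2)cc1` differs from compound 3 by 3,4-difluorophenyl in place of 2,4-difluorophenyl on a saturated chain carbon, two bonds along the chain from an oxygen on an aromatic ring. Neither measured step touches this change, since each of them swaps the whole aryl group rather than moving one fluorine within it. Compound 4 is therefore expected to sit near compound 3, with a step of a 1.1-fold higher number from compound 3 to compound 4 (0.05 log units; within the scatter) in this assay, none beyond the scatter. The estimate for compound 4 is 1.2 h, with a range from 0.6 h to 2.4 h.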

Compound 4, half-life: > 2 h
Compound 4: a limit, no number; the forecaster's own chance of this, stated with the estimate: 20%; middle value at least 1.6-fold (0.22 log units) away from the limit.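

Exchanging 2,4-difluorophenyl for 3,4-difluorophenyl, on a saturated chain carbon two bonds along the chain from an oxygen on an aromatic ring, rearranges the same atoms and gives an at least 1.8-fold higher number from compound 3 to compound 4 (0.26 log units; that floor lies within the scatter). The steps joining compound 4 to compound 1 and to compound 2 link two limits and cannot be read. In this assay, this leaves compound 3 as the only compound with a read number, while the other three share one limit of the assay: the limit of > 2 h in this assay, at which 3 of the 4 values shown sit.

On these data alone, how long compound 1, compound 2 and compound 4 actually last remains open, so no order among them can be given. Also open, as far as these compounds go, is whether a 2-fluorophenyl or a 2-chloro-4-fluorophenyl group at this place would give a read number, as the 2,4-difluorophenyl group of compound 3 does.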